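The source may report more compounds than this note shows. Statements on the series, on what has been measured and on what is new or still open speak of the compounds shown alone.

Compound 1 `CN(C)CCCCCCCOc1ccc2oc(-c3ccccc3)cc(=O)c2c1`: 165 nM
Compound 2 `O=c1cc(-c2ccccc2)oc2ccc(OCCCCCCN3CCC(O)CC3)cc12`: 100 nM
Compound 3 `CN(CCCCCCOc1ccc2oc(-c3ccccc3)cc(=O)c2c1)Cc1ccccc1`: 52 nM

All three were measured in an assay on isolated protein (Cavia porcellus) with Sigma non-opioid intracellular receptor 1 (Homo sapiens) as the target, read by radioligand binding; a lower number here means a stronger inhibitor, a higher number a weaker inhibitor. Compound 2 sits between the other two: toward compound 1 the step is a 1.7-fold lower number from compound 1 to compound 2 (0.22 log units; within the scatter), toward compound 3 it is a 1.9-fold lower number from compound 2 to compound 3 (0.28 log units; within the scatter), so the three lie close together and none can be called stronger than another. Within the data shown here, the only step beyond the scatter is a 3.2-fold lower number from compound 1 to compound 3 (0.50 log units; beyond the scatter), and every measured step changes the amine at the end of the chain. Compound 4 `O=c1cc(C2CCCCC2)oc2ccc(OCCCCCCN3CCC(O)CC3)cc12` brings a change of another kind: cyclohexyl in place of phenyl on an aromatic carbon. Among the measured compounds shown here, no measured step touches this position, so there is no direct guide. Compound 4 is expected to stay near compound 2, an expected step of a 1.3-fold higher number from compound 2 to compound 4 (0.11 log units; within the scatter). Compound 4 is therefore estimated at 130 nM, within 40 nM to 400 nM.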

Compound 4, half-maximal inhibitory concentration: 88 nM
Estimate against measurement, compound 4: 1.5-fold (0.17 log units) above, and the stated range covers the measured number.
By their numbers in this assay, from the lowest: compounds 3, 4, 2 and 1 (each within the scatter of the next, the first and the last beyond it).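

In this assay cyclohexyl in place of phenyl next to the ring oxygen gives a 1.1-fold lower number from compound 2 to compound 4 (0.06 log units; within the scatter) and so, with this chain and amine, an aromatic ring at this place is not needed to keep the number in the same range. Among these compounds, this is the first view of a change away from the amine end of the chain. Nothing measured here explains the result.

Still open, from the compounds shown here alone, is how a methyl group or a pyridine ring would fare at this place. Also open, going by these compounds, is whether cyclohexyl gives the same result with the benzyl(methyl)amino end of compound 3.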